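A few compounds are considered here, and "the series" means these few. Any claim that something is new, unique, unknown or untested is made for them only; others in the source may bear on it.

Compound 2 `O=c1oc(-c2ccccc2I)nc2cc(Cl)ccc12` carries a chloro group on the core it shares with compound 1 `O=c1oc(-c2ccccc2I)nc2ccccc12`. In an assay on isolated protein for inhibition of complement C1r subcomponent (Homo sapiens) (a higher number here means a weaker inhibitor, a lower number a stronger inhibitor), compound 1 gives 16700 nM. For compound 2 this assay reports only a limit, > 62500 nM. Compound 3 `O=c1oc(-c2ccccc2I)nc2cc(Cl)c(Cl)cc12`, bearing a second chloro, likewise reaches only a limit of > 62500 nM. Compound 2 thus sits at the limit of this assay, weaker than compound 1: the step of an at least 3.7-fold higher number from compound 1 to compound 2 (0.57 log units; beyond the scatter) is beyond the scatter, while a step that the two limits leave unreadable from compound 2 to compound 3 cannot be read because of the limit (the limit of > 62500 nM in this assay, at which 2 of the 3 values shown sit). Compound 4 `Cc1ccc2c(=O)oc(-c3ccccc3I)nc2c1` differs from compound 2 by methyl in place of chloro on an aromatic carbon. Going by the values given here, only the step from compound 1 to compound 2 bears on this position, and it suggests a substituent there gives a weaker inhibitor, so compound 4 is expected to stay close to compound 2, with an at least 1.5-fold lower number from compound 2 to compound 4 (0.19 log units; that floor lies within the scatter) expected within the scatter. Compound 4 is therefore estimated at 40000 nM in this assay, between 12000 nM and 62500 nM.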

Compound 4, half-maximal inhibitory concentration: > 62500 nM
Compound 4 gave a limit, no number; the forecaster's own chance of this, stated with the estimate: 40%; middle value at least 1.5-fold (0.19 log units) away from the limit.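

In this assay, methyl in place of hydrogen on this aromatic carbon gives an at least 3.7-fold higher number from compound 1 to compound 4 (0.57 log units; beyond the scatter), so the weakening seen with chloro at this position is not confined to chloro. For compound 4 the assay again reports only a limit, > 62500 nM. The step between chloro and methyl cannot be read, so the two groups cannot be ranked here: the limit of > 62500 nM in this assay, at which 3 of the 4 values shown sit.

From the compounds shown here alone, it remains open whether any group on this carbon, such as an amine or a carboxylic acid, would match compound 1. Going by these compounds, how much weaker compound 2 and compound 4 truly are also remains open.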